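This account rests on a few compounds, and the source may have more. Where it says the series, first, only, none or still open, it means among the compounds named here.

In a functional assay on the whole organism (blood) with Rattus norvegicus as the target, with stated times of 24 h and 1 h, at a dose of 5 mg/kg by the intraperitoneal route (a higher number here means a stronger effect of the compound at the dose given, a lower number a weaker effect), compound 1 `CC(=O)NCCC1CCN(S(=O)(=O)NC(=O)NC[C@@H]2C[C@@H]3C=C[C@@H]2C3)CC1` gives 18%, compound 2 `Cc1ncsc1C(=O)NCCC1CCN(S(=O)(=O)NC(=O)NC[C@@H]2C[C@@H]3C=C[C@@H]2C3)CC1` gives 11%, and compound 3 `O=C(NC[C@@H]1C[C@@H]2C=C[C@@H]1C2)NS(=O)(=O)N1CCC(CCNC(=O)c2nc3ccccc3s2)CC1` gives 24%. Compound 3 stands above compound 2 by a number 13 percentage points higher from compound 2 to compound 3 (beyond the scatter), beyond the scatter, while compound 1 and compound 3 lie within the scatter of each other, as do compound 1 and compound 2.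

Compound 4 `O=C(NC[C@@H]1C[C@@H]2C=C[C@@H]1C2)NS(=O)(=O)N1CCC(CCNC(=O)c2cc(Cl)cc3cccnc23)CC1` differs from compound 3 in one place: 6-chloroquinolin-8-yl in place of 1,3-benzothiazol-2-yl on a carbonyl carbon. All three measured steps also change the group on that carbonyl carbon, namely a number 7 percentage points lower from compound 1 to compound 2 (within the scatter), a number 6 percentage points higher from compound 1 to compound 3 (within the scatter) and a number 13 percentage points higher from compound 2 to compound 3 (beyond the scatter). Only one of them leaves the scatter, and none exchanges one fused bicyclic aromatic group for another, so they give no direct guide for this particular swap. Compound 4 is therefore expected to give a number close to that of compound 3, with a step of a number 4 percentage points lower from compound 3 to compound 4 (within the scatter) that is not expected to exceed the scatter. The estimate for compound 4 in this assay is 20%, expected to fall between 8% and 32%.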

Compound 4, a percentage reported as activity, at one dose (the size of the read-out at that dose, not a potency): 35%
Compound 4: middle estimate off by 15 percentage points, on the low side, outside the stated range (above it).
By their numbers in this assay, from the lowest: compounds 2, 1 and 3 (each within the scatter of the next, the first and the last beyond it); then compound 4.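

In this assay, the group on the carbonyl carbon can move the read-out beyond the scatter in the upward direction, with 6-chloroquinolin-8-yl giving a number 11 percentage points higher from compound 3 to compound 4 (beyond the scatter) and a number 24 percentage points higher from compound 2 to compound 4 (beyond the scatter) and also a number 17 percentage points higher from compound 1 to compound 4 (beyond the scatter) at this place. Going by these compounds alone, compound 4 is therefore the highest of the four, and exchanging one fused bicyclic aromatic group for another here proves not to be neutral, which the earlier steps could not show. Nothing in the data shown accounts for this gain.

The share of the chlorine and that of the quinoline remain unseparated, and a plain quinolin-8-yl or a 6-fluoroquinolin-8-yl on the same carbonyl carbon would tell them apart. On these data alone, whether the order of the compounds holds at other doses also stays open.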